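The source may report more compounds than this note shows. Statements on the series, on what has been measured and on what is new or still open speak of the compounds shown alone.

Measured compounds:
Compound 1, `COc1ccc(/C=C2\CCCc3ccccc3C2=O)cc1`: 470 nM
Compound 2, `CN(C)c1ccc(/C=C2\CCCc3ccccc3C2=O)cc1`: 5250 nM
Compound 3, `COc1ccc(/C=C2\CCCCCC2=O)cc1`: 250000 nM

In a functional assay on MOLT-4 cells (Homo sapiens) for inhibition (on this read-out higher numbers stand for weaker inhibition and lower numbers for stronger inhibition), compound 1 gives the lowest of the three numbers. Compound 2 differs from it in one place, (dimethylamino in place of methoxy on an aromatic carbon), and this change gave an 11-fold higher number from compound 1 to compound 2 (1.05 log units; beyond the scatter) in this assay. Compound 3 shares the para-substituted aromatic ring and the enone linkage with compound 1 but rests on a different core; how the two cores differ is not broken down here. In this assay compound 3 stands highest of the three, and its number lies well beyond the scatter from both compound 1 and compound 2.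

Compound 4, `CN(C)c1ccc(/C=C2\CCCCCC2=O)cc1`, is not yet measured. It differs from compound 3 by dimethylamino in place of methoxy on an aromatic carbon. This is the same kind of change as that from compound 1 to compound 2, though the group standing para to the substituent is described once as a group of 9 heavy atoms and once as a large group, so the surroundings are not identical.

Because the same kind of change gave an 11-fold higher number from compound 1 to compound 2 (1.05 log units; beyond the scatter) on the core of compound 1, compound 4 is expected to show a step of about a 4.8-fold higher number from compound 3 to compound 4 (0.68 log units; beyond the scatter) from compound 3 in this assay, the only shown precedent. Since compound 3 already gives a very high number, the assay may well report only a limit for compound 4. The estimate for compound 4 in this assay is 1200000 nM, between 250000 nM and 6000000 nM.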

Compound 4, half-maximal inhibitory concentration: 57400 nM
The estimate for compound 4 lay 21-fold (1.32 log units) above the measured number; the measured number lies below the stated range.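

In this assay, putting dimethylamino in place of methoxy on the second core gave a 4.4-fold lower number from compound 3 to compound 4 (0.64 log units; beyond the scatter), so the direction seen on the core of compound 1 did not carry over. The two steps run opposite ways, and the gap between them is larger than chance repetition would explain: the same change on two cores in this assay, an 11-fold higher number (1.05 log units; beyond the scatter) from compound 1 to compound 2 and a 4.4-fold lower number (0.64 log units; beyond the scatter) from compound 3 to compound 4, 49-fold (1.69 log units) apart, beyond the scatter of two such steps This shows that, for these two pairs, the outcome of the change depends on the core it is made on, and that a step measured on one core is a poor guide to the step on the other; it does not show which difference between the cores is responsible, nor how the change would behave on any further core.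

The compounds shown leave open whether a free amino group, a hydroxyl or a morpholine in the same place would also split between the two cores. They also leave open whether the reversal belongs to dimethylamino and methoxy alone or extends to other pairs of groups.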